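Chlorophenyl triazole sulfonamides: forecasting a matched pair

A few compounds are considered here, and "the series" means these few. Any claim that something is new, unique, unknown or untested is made for them only; others in the source may bear on it.

Three compounds measured so far in a functional assay on HepG2 cells (Homo sapiens) for antiproliferative activity, read by MTT assay, with a stated time of 24 h; a higher number here means a weaker inhibitor, a lower number a stronger inhibitor:

compound 1 `O=c1[nH]cc(S(=O)(=O)Nc2ccccc2-c2cn(-c3ccccc3Cl)nn2)c(=O)[nH]1` gives 2240 nM
compound 2 `O=c1[nH]cc(S(=O)(=O)Nc2ccccc2-c2cn(-c3cccc(Cl)c3)nn2)c(=O)[nH]1` gives 2460 nM
compound 3 `O=c1[nH]cc(S(=O)(=O)Nc2ccc(-c3cn(-c4ccccc4Cl)nn3)cc2)c(=O)[nH]1` gives 2230 nM

All three values sit within the usual scatter of one another, so no order among them is claimed. Compound 1 and compound 2 form a matched pair: the change is 3-chlorophenyl in place of 2-chlorophenyl on an aromatic nitrogen, and the step it made in this assay is a 1.1-fold higher number from compound 1 to compound 2 (0.04 log units; within the scatter). Compound 3 carries a different core from compound 1; the difference between the two cores is not broken down here.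

Compound 4 `O=c1[nH]cc(S(=O)(=O)Nc2ccc(-c3cn(-c4cccc(Cl)c4)nn3)cc2)c(=O)[nH]1` is not yet measured. It stands to compound 3 as compound 2 stands to compound 1: the change is 3-chlorophenyl in place of 2-chlorophenyl on an aromatic nitrogen, the same change at the same place. For the measured compounds named here, the only precedent for this change, the step from compound 1 to compound 2, stayed within the scatter. The expectation for compound 4 in this assay is therefore a step of a 1.1-fold higher number from compound 3 to compound 4 (0.03 log units; within the scatter), resting on that single precedent.

Compound 4 is estimated at 2400 nM, with a range of 1500 nM to 3900 nM expected.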

Compound 4, half-maximal inhibitory concentration: 2020 nM
For compound 4 the middle estimate is 1.2-fold (0.07 log units) above the measured one, and the stated range covers the measured number.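

In this assay, 3-chlorophenyl in place of 2-chlorophenyl on an aromatic nitrogen gives a 1.1-fold lower number from compound 3 to compound 4 (0.04 log units; within the scatter), so on the core of compound 3 the change again stays within the scatter. The two steps do not separate from each other: the same change on two cores in this assay, a 1.1-fold higher number (0.04 log units; within the scatter) from compound 1 to compound 2 and a 1.1-fold lower number (0.04 log units; within the scatter) from compound 3 to compound 4, 1.2-fold (0.08 log units) apart, within the scatter of two such steps. Across these two cores, the exchange of 2-chlorophenyl for 3-chlorophenyl therefore has no readable effect in this assay, but the opposite directions of the two steps carry no meaning, and two flat steps cannot show whether a change with a real effect would carry from one core to the other.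

As far as these compounds go, all four compounds carry a chlorophenyl group on the aromatic nitrogen, so it remains open whether the chlorine matters at all, which an unsubstituted phenyl would test. Also open, from the compounds shown here alone, is whether the number would move with a group of a different kind at the same place, such as an aminophenyl, a carboxyphenyl or a longer alkyl chain.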